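A few compounds are considered here, and "the series" means these few. Any claim that something is new, unique, unknown or untested is made for them only; others in the source may bear on it.

Three compounds here share one core and differ only in the group attached to the carbonyl carbon. Compound 1 `O=C(N1CCC(F)CC1)N1CC(c2nc(-c3cccc(Cl)c3)no2)C1` carries 4-fluoropiperidin-1-yl there, and in an assay on HEK293 cells for positive allosteric modulation of metabotropic glutamate receptor 5 (Homo sapiens), read by FLIPR (a higher number here means that more compound is needed for the effect, a lower number that less compound is needed), compound 1 gives 990 nM. Compound 2 `O=C(c1ccccc1F)N1CC(c2nc(-c3cccc(Cl)c3)no2)C1` carries 2-fluorophenyl instead, and compound 3 `O=C(c1ccc(F)cc1)N1CC(c2nc(-c3cccc(Cl)c3)no2)C1` carries 4-fluorophenyl. For compound 2 the outcome in this assay is only a limit, > 10000 nM. For compound 3 the outcome is likewise a limit, > 10000 nM. Compound 3 therefore sits at the edge of what this assay can report, a point it shares with compound 2 (the limit of > 10000 nM in this assay, at which 2 of the 3 values shown sit). Both aromatic replacements cost heavily: an at least 10-fold higher number from compound 1 to compound 2 (1.00 log units; beyond the scatter), and an at least 10-fold higher number from compound 1 to compound 3 (1.00 log units; beyond the scatter). Between the two aromatic compounds, a step that the two limits leave unreadable from compound 2 to compound 3.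

Compound 4 `O=C(N1CCCCC1)N1CC(c2nc(-c3cccc(Cl)c3)no2)C1` is the compound still to be measured; it differs from compound 3 as follows. piperidin-1-yl in place of 4-fluorophenyl on a carbonyl carbon This is the reverse of the kind of change that separated compound 1 from compound 3, so a strong fall in the number is expected, tempered only by the missing fluorine of compound 1. Compound 4 is expected to give 1500 nM in this assay, with a range from 500 nM to 5000 nM. The expected step is thus an at least 6.6-fold lower number from compound 3 to compound 4 (0.82 log units; beyond the scatter).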

Compound 4, half-maximal effective concentration: 370 nM
The estimate for compound 4 lay 4.1-fold (0.61 log units) above the measured number; measured number outside the range, below it.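

Compound 4 shows that an unsubstituted saturated ring on the carbonyl carbon is enough for a readable result in this assay, with no fluorine needed: the change from the aromatic rings gives an at least 27-fold lower number from compound 3 to compound 4 (1.43 log units; beyond the scatter) and an at least 27-fold lower number from compound 2 to compound 4 (1.43 log units; beyond the scatter). These two steps start from compounds whose outcomes are only limits of the assay, not numbers, so each gives a minimum size: the limit of > 10000 nM in this assay, at which 2 of the 4 values shown sit. Removing the fluorine from the saturated ring of compound 1 gives a 2.7-fold lower number from compound 1 to compound 4 (0.43 log units; beyond the scatter), a new finding that this fluorine is not required and that its absence leaves compound 4 with the lowest number of the four.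

The compounds shown do not separate the effect of the aromatic ring from that of the fluorine on it, a question that plain phenyl on the carbonyl carbon would address. On these data alone, how far the saturated ring can change also remains open, for example whether pyrrolidin-1-yl, with a smaller ring, or morpholin-4-yl, with an added ring oxygen, would keep the number as low as in compound 4.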